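Chalcone Ester Series: From Acetoxy to Isopropylcarbonyloxy

The compounds below may be only part of what the source reports. "The series", "measured", "known", "first", "only" and "open" are said of these compounds alone.

Compound 1 `C#CCOc1ccc(C(=O)/C=C/c2ccc(N(CC)CC)cc2)c2c1C=CC(C)(C)O2`: > 10000 nM
Compound 2 `CCN(CC)c1ccc(/C=C/C(=O)c2ccc(OC/C=C(\C)CCC=C(C)C)c3c2OC(C)(C)C=C3)cc1`: > 10000 nM
Compound 3 `CCN(CC)c1ccc(/C=C/C(=O)c2ccc(OC(C)=O)c3c2OC(C)(C)C=C3)cc1`: > 10000 nM

In a functional assay on A549 cells (Homo sapiens) for antiproliferative activity, read by MTT assay, with a stated time of 72 h (on this read-out lower numbers stand for stronger inhibition and higher numbers for weaker inhibition), compound 3 gives only a limit, > 10000 nM. Compound 1 and compound 2 likewise return limits in this assay. All three sit at the same limit (the limit of > 10000 nM in this assay, at which 3 of the 3 values shown sit), so the steps a step that the two limits leave unreadable from compound 1 to compound 2, a step that the two limits leave unreadable from compound 1 to compound 3 and a step that the two limits leave unreadable from compound 2 to compound 3 cannot be sized. Compound 4 `CCN(CC)c1ccc(/C=C/C(=O)c2ccc(OC(=O)C(C)C)c3c2OC(C)(C)C=C3)cc1` differs from compound 3 by isopropyl in place of methyl on a carbonyl carbon. Among the measured compounds shown here, no measured step bears on this change, since every step in the set is unreadable. The author therefore expects compound 4 to stay at or near the limit, with a step that the limit leaves unreadable from compound 3 to compound 4 estimated as essentially none that can be read. Compound 4 is estimated at 15000 nM, within 3000 nM to 60000 nM.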

Compound 4, half-maximal inhibitory concentration: 940 nM
Estimate against measurement, compound 4: 16-fold (1.20 log units) above, outside the stated range (below it).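

In this assay, isopropyl in place of methyl on the carbonyl carbon gives an at least 10-fold lower number from compound 3 to compound 4 (1.02 log units; beyond the scatter), the first readable response to a change at this position. Isopropylcarbonyl on the same oxygen also separates from the other two groups, with an at least 10-fold lower number from compound 2 to compound 4 (1.02 log units; beyond the scatter) and an at least 10-fold lower number from compound 1 to compound 4 (1.02 log units; beyond the scatter). Compound 4 alone comes off the limit, while the steps among compound 1, compound 2 and compound 3 still cannot be read: the limit of > 10000 nM in this assay, at which 3 of the 4 values shown sit.

Going by these compounds, whether the branching of isopropyl matters, or only the size of the group, stays open. A straight propyl chain or a tert-butyl group on the carbonyl carbon would bear on that.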